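The source may hold more compounds than are shown below. What is called first, only, known or untested is meant among the compounds shown, and "the series" means these compounds.

Three compounds share one core and differ only in the group carried on the aromatic ring. Compound 1 `CC(Oc1ccccc1Br)C1=NCCN1` gives 355 nM in an assay on CHO cells for displacement of a labelled ligand from Alpha-2B adrenergic receptor (Homo sapiens); a lower number here means a stronger inhibitor, a higher number a weaker inhibitor. Compound 2 `C=C(C)c1ccccc1OC(C)C1=NCCN1` gives 871 nM in this assay, and compound 3 `CCOc1ccccc1OC(C)C1=NCCN1` gives 1320 nM. Compound 3 thus shows the highest of the three numbers, though the step of a 1.5-fold higher number from compound 2 to compound 3 (0.18 log units; within the scatter) stays within the scatter, whereas the step of a 3.7-fold higher number from compound 1 to compound 3 (0.57 log units; beyond the scatter) goes beyond it, as does the step of a 2.5-fold higher number from compound 1 to compound 2 (0.39 log units; beyond the scatter). Compound 4 `CC(C)Oc1ccccc1OC(C)C1=NCCN1` differs from compound 3 by methyl in place of hydrogen on a saturated chain carbon bound to an oxygen on an aromatic ring and a saturated chain carbon. Among the measured compounds shown here, no measured step lengthens an alkoxy chain; the two steps beyond the scatter both exchange bromo for another group, and the only step between two oxygen-bearing or carbon-bearing substituents of similar size is the one within the scatter. The author therefore expects, in this assay, a step of a 1.0-fold lower number from compound 3 to compound 4 (0.01 log units; within the scatter) that does not clear the scatter. Compound 4 is estimated at 1300 nM, with a range from 500 nM to 3500 nM.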

Compound 4, inhibition constant: 1580 nM
Beside the measured number, compound 4's estimate is 1.2-fold (0.08 log units) below it, and the stated range covers the measured number.
By their numbers in this assay, from the lowest: compound 1; then compounds 2, 3 and 4 (each within the scatter of the next).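

In this assay, among the compounds shown here, this is the one step that alters the alkoxy chain itself: ethoxy to isopropoxy gives a 1.2-fold higher number from compound 3 to compound 4 (0.08 log units; within the scatter), so methyl in place of hydrogen on this saturated chain carbon leaves the number within the scatter. Isopropoxy in place of 1-methylethenyl likewise stays within the scatter, with a 1.8-fold higher number from compound 2 to compound 4 (0.26 log units; within the scatter), whereas isopropoxy in place of bromo gives a 4.5-fold higher number from compound 1 to compound 4 (0.65 log units; beyond the scatter), so that compound 1 alone stands apart from the other three compounds. Nothing shown here gives a reason for these steps.

The compounds shown leave open whether a methoxy group or a longer chain such as butoxy on the aromatic carbon would also stay within the scatter of compound 4. They also leave open whether chloro or iodo in place of bromo would keep the number of compound 1.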